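A few compounds are considered here, and "the series" means these few. Any claim that something is new, unique, unknown or untested is made for them only; others in the source may bear on it.

Three compounds share one core and differ only in the group attached to an amide-type nitrogen. Compound 1 `COc1cc(NC(C)CCCNC(=O)NNC(=O)Nc2cccc(F)c2)c2ncccc2c1` carries a ((3-fluorophenyl)carbamoyl)amino group there, and in a functional assay on MIA PaCa-2 cells (Homo sapiens) for inhibition, read by MTT assay, with a stated time of 72 h (a lower number here means a stronger inhibitor, a higher number a weaker inhibitor), compound 1 gives 69000 nM. Compound 2 `COc1cc(NC(C)CCCNC(=O)Nc2ccc(O)cc2)c2ncccc2c1` bears a 4-hydroxyphenyl on that nitrogen instead, and compound 2 gives 57000 nM, so that a 1.2-fold lower number from compound 1 to compound 2 (0.08 log units; within the scatter). Compound 3 `COc1cc(NC(C)CCCNC(=O)NNC(=O)Nc2ccc(F)cc2)c2ncccc2c1` is the 4-fluorophenyl counterpart of compound 1. For compound 3 only a limit of the assay is known, >= 250000 nM, which is the limit of >= 250000 nM in this assay, at which 1 of the 3 values shown sits. Compound 3 stands as the weakest of the three, since an at least 3.6-fold higher number from compound 1 to compound 3 (0.55 log units; beyond the scatter) and an at least 4.3-fold higher number from compound 2 to compound 3 (0.64 log units; beyond the scatter).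

Compound 4 `COc1cc(NC(C)CCCNC(=O)Nc2cccc(F)c2)c2ncccc2c1` has not yet been measured. Compared with compound 3 it shows (3-fluorophenyl in place of ((4-fluorophenyl)carbamoyl)amino on an amide-type nitrogen). This single change undoes both measured losses at once: the 3-fluorophenyl of compound 1 comes back, and the ((4-fluorophenyl)carbamoyl)amino group that separates compound 3 from compound 2 is gone. Both steps that end at compound 3 were at least modest losses, so a gain of comparable size is expected, that is an at least 4.5-fold lower number from compound 3 to compound 4 (0.65 log units; beyond the scatter). Compound 4 is therefore estimated to give about 55000 nM, with a likely range from 20000 nM to 150000 nM.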

Compound 4, half-maximal inhibitory concentration: 22000 nM
Estimate against measurement, compound 4: 2.5-fold (0.40 log units) above, within the range that was stated.
By their numbers in this assay, from the lowest: compound 4; then compounds 2 and 1 (each within the scatter of the next). At a limit, above all of these: compound 3.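

In this assay, compounds 1 and 2 sat within the scatter of each other, so the group on this amide-type nitrogen seemed to matter little, but a 3-fluorophenyl there separates from both, with a 3.1-fold lower number from compound 1 to compound 4 (0.50 log units; beyond the scatter) and a 2.6-fold lower number from compound 2 to compound 4 (0.41 log units; beyond the scatter), which makes compound 4 the most potent of the four. The first of these steps keeps the 3-fluorophenyl ring and removes only the carbamoyl-amino stretch that links it to the nitrogen, so in this pair the shorter attachment gives the lower number, and the largest step, an at least 11-fold lower number from compound 3 to compound 4 (1.05 log units; beyond the scatter), points the same way. The value of compound 3 is a limit and not a number, so that step gives no exact size: the limit of >= 250000 nM in this assay, at which 1 of the 4 values shown sits.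

Compounds 1 and 3 differ in where the fluorine sits, but the shorter series offers no such comparison, as a 4-fluorophenyl or a plain phenyl directly on this nitrogen is not among the compounds shown. Also open, as far as these compounds go, is how an amine or a carboxylic acid on this ring, or a longer chain in the shared core, would change the number.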